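A Chlorothiazole Amide Following Three Inactive Analogues

The source may hold more compounds than are shown below. What is called first, only, known or untested is meant among the compounds shown, and "the series" means these compounds.

Compound 3 `O=C(Nc1cccc(-c2nc3ccccc3s2)c1)c1ccnc(Cl)c1` shares its core with compound 1 `C=C(C)C(=O)Nc1cccc(-c2nc3ccccc3s2)c1` and compound 2 `O=C(O)/C=C/C(=O)Nc1cccc(-c2nc3ccccc3s2)c1`, the three differing only in the group carried by the amide carbonyl carbon. In an ADME assay on Raji cells (Homo sapiens) for inhibition, with a stated time of 72 h (a higher number here means that more compound is needed for the effect, a lower number that less compound is needed), compound 1 gives > 25000 nM, which is a limit of the assay and not a number. Compound 2 likewise reaches only the limit > 25000 nM. Compound 3 also stands at the limit > 25000 nM. Because all three sit at the limit of > 25000 nM in this assay, at which 3 of the 3 values shown sit, none of the steps among them can be read: a step that the two limits leave unreadable from compound 1 to compound 2, a step that the two limits leave unreadable from compound 1 to compound 3 and a step that the two limits leave unreadable from compound 2 to compound 3 are each left open by the two limits, so compound 3 cannot be placed above or below its two companions. Compound 4 `O=C(Nc1cccc(-c2nc3ccccc3s2)c1)c1cnc(Cl)s1` differs from compound 3 in one place: 2-chloro-1,3-thiazol-5-yl in place of 2-chloropyridin-4-yl on a carbonyl carbon. The three measured steps bear on this change only in that every variation of the group on the carbonyl carbon so far has remained at the limit, and none of them yields a readable size or direction. The estimate therefore keeps compound 4 at the limit, with the step that the limit leaves unreadable from compound 3 to compound 4 expected to be none beyond the scatter. Compound 4 is expected to give about 40000 nM in this assay, with a range from 15000 nM to 120000 nM.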

Compound 4, half-maximal effective concentration: > 25000 nM
Compound 4: no number, only a limit (the forecaster's own chance of this, stated with the estimate: 80%); the middle value does not contradict the limit.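

In this assay compound 4 also gives only a limit, so its steps to compound 1, compound 2 and compound 3 cannot be read, and the four cannot be placed in any order: the limit of > 25000 nM in this assay, at which 4 of the 4 values shown sit. The compounds shown leave open whether any group on the carbonyl carbon of the shared core gives a readable value in this assay.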